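A few compounds are considered here, and "the series" means these few. Any claim that something is new, unique, unknown or untested is made for them only; others in the source may bear on it.

Measured so far in an ADME assay on CCRF-CEM cells (Homo sapiens) for cytotoxicity, with a stated time of 72 h; a higher number here means a weaker inhibitor, a lower number a stronger inhibitor:
compound 1, `Clc1ccc(Cc2nn3c(Br)c(-c4ccc(Cl)cc4)nc3s2)cc1`: compound 1 reports only a limit, > 250000 nM
compound 2, `Clc1ccc(Cc2nn3c(Br)c(-c4ccc(Br)cc4)nc3s2)cc1`: compound 2 gives 238000 nM
compound 3, `COc1ccc(-c2nc3sc(Cc4ccc(Cl)cc4)nn3c2Br)cc1`: compound 3 gives 58000 nM

Compound 3 holds the lowest of the two numbers. The nearest number is that of compound 2, and the step of a 4.1-fold lower number from compound 2 to compound 3 (0.61 log units; beyond the scatter) lies beyond the scatter. Compound 1 sits at the limit of > 250000 nM in this assay, at which 1 of the 3 values shown sits. The step of an at least 4.3-fold lower number from compound 1 to compound 3 (0.63 log units; beyond the scatter) likewise lies beyond the scatter.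

Compound 4, `Clc1ccc(Cc2nn3c(Br)c(-c4ccc(Cl)cc4Cl)nc3s2)cc1`, differs from compound 3 by 2,4-dichlorophenyl in place of 4-methoxyphenyl on an aromatic carbon. Both measured steps bear on it when read backwards: replacing methoxy with a halogen raised the number by a modest amount in this assay. For the measured compounds named here, no measured step covers the second chlorine of the entering group. A modest rise is therefore expected, a 3.4-fold higher number from compound 3 to compound 4 (0.54 log units; beyond the scatter). The estimate for compound 4 is 200000 nM, with a range from 60000 nM to 400000 nM, and a fair chance that only a limit is reported.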

Compound 4, half-maximal inhibitory concentration: 106000 nM
Compound 4: the middle estimate sits 1.9-fold (0.28 log units) above what was measured; low and high end bracket the measured number.
By their numbers in this assay, from the lowest: compounds 3 and 4 (each within the scatter of the next); then compound 2. At a limit, above all of these: compound 1.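

At this aromatic carbon, a halogenated phenyl no longer stands clearly apart from 4-methoxyphenyl in this assay: the change gives a 1.8-fold higher number from compound 3 to compound 4 (0.26 log units; within the scatter). The earlier gap between methoxy and halogen therefore does not carry over to 2,4-dichlorophenyl, which also departs from 4-bromophenyl, with a 2.2-fold lower number from compound 2 to compound 4 (0.35 log units; beyond the scatter). A second chloro on the ring gives an at least 2.3-fold lower number from compound 1 to compound 4 (0.37 log units; beyond the scatter), a step read from compound 1, whose value is only a limit: the limit of > 250000 nM in this assay, at which 1 of the 4 values shown sits.

Whether the second chlorine works the same way at other ring carbons stays open, with one such compound shown. On these data alone, how an amine or a carboxylic acid on this phenyl group would read in this assay also stays open.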